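This account rests on a few compounds, and the source may have more. Where it says the series, first, only, none or still open, it means among the compounds named here.

Compound 1 `O=C(/C(=C\c1ccc(OCc2ccccc2)cc1)SCc1ccc(Cl)cc1)c1ccc(Cl)cc1` and compound 2 `COc1cc(OC)c(/C=C(/SCc2ccc(Cl)cc2)C(=O)c2ccc(Br)cc2)c(OC)c1` both carry a (4-chlorobenzyl)sulfanyl group on a double-bonded chain carbon bound to a carbonyl carbon and a double-bonded chain carbon; the difference between the two cores is not broken down here. In a functional assay on DU-145 cells (Homo sapiens) for inhibition, read by trypan blue exclusion, with a stated time of 96 h (on this read-out lower numbers stand for stronger inhibition of growth and higher numbers for weaker inhibition of growth), compound 1 gives 1000 nM, and compound 2 gives 1000 nM, the two being level at the digits reported and together the lowest of the three measured numbers. Compound 3 `COc1cc(OC)c(/C=C(\C(=O)c2ccc(Br)cc2)S(=O)(=O)Cc2ccc(Cl)cc2)c(OC)c1` differs from compound 2 in one place, ((4-chlorobenzyl)sulfonyl in place of (4-chlorobenzyl)sulfanyl on a double-bonded chain carbon bound to a carbonyl carbon and a double-bonded chain carbon). In this assay compound 3 gives 25000 nM, so the step of a 25-fold higher number from compound 2 to compound 3 (1.40 log units; beyond the scatter) is large and beyond the scatter. Compound 4 `O=C(/C(=C\c1ccc(OCc2ccccc2)cc1)S(=O)(=O)Cc1ccc(Cl)cc1)c1ccc(Cl)cc1` has not been measured; it differs from compound 1 by the same change, ((4-chlorobenzyl)sulfonyl in place of (4-chlorobenzyl)sulfanyl on a double-bonded chain carbon bound to a carbonyl carbon and a double-bonded chain carbon), made at a place described in the same words. Among the compounds with values here, because the single measured instance of this change gave a 25-fold higher number from compound 2 to compound 3 (1.40 log units; beyond the scatter), compound 4 is expected to show a comparable weakening, with a step of about a 20-fold higher number from compound 1 to compound 4 (1.30 log units; beyond the scatter) in this assay. Compound 4 is therefore estimated at 20000 nM, expected to lie between 5000 nM and 60000 nM.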

Compound 4, concentration for 50% growth inhibition: 1000 nM
The estimate for compound 4 lay 20-fold (1.30 log units) above the measured number; the whole stated range lies above it.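

In this assay, putting (4-chlorobenzyl)sulfonyl in place of (4-chlorobenzyl)sulfanyl gives no change at the digits printed from compound 1 to compound 4 (within the scatter). The change therefore does not carry a fixed size from one core to another in this series, and its size on one core did not predict its size on the other: the same change on two cores in this assay, a 25-fold higher number (1.40 log units; beyond the scatter) from compound 2 to compound 3 and no change at the digits printed (within the scatter) from compound 1 to compound 4, 25-fold (1.40 log units) apart, beyond the scatter of two such steps This shows only that the outcome differed on these two cores; the cores differ from each other in more than one place, so the pair cannot tell which part of either core goes with the large step or the absence of one, and it gives no reason for the difference.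

The compounds shown leave open how the same change would behave on further cores, such as one carrying an amine or a carboxylic acid. They also leave open what a sulfinyl group would do at the same place, on a double-bonded chain carbon bound to a carbonyl carbon and a double-bonded chain carbon.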